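Removing the benzyl from the indole nitrogen of compound 1

A few compounds are considered here, and "the series" means these few. Any claim that something is new, unique, unknown or untested is made for them only; others in the source may bear on it.

Measured compounds:
compound 1 `c1ccc(Cn2c(-c3nc4ccccc4[nH]3)cc3ccccc32)cc1` gives 21500 nM in a functional assay on T47D cells (Homo sapiens) for antiproliferative activity, read by MTT assay, with a stated time of 48 h; on this read-out lower numbers stand for stronger inhibition and higher numbers for weaker inhibition
compound 2 `O=C(c1ccccc1)c1ccc2[nH]c(-c3cc4ccccc4n3Cc3ccccc3)nc2c1` gives "not determined" (no result reported) in this assay

Going by the values given here, compound 1 carries the only number in this assay; compound 2 gives no value there, so the series offers no measured step between two compounds. Compound 1 therefore stands alone, and its number places it as a weak inhibitor on this read-out.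

Compound 3 `c1ccc2[nH]c(-c3nc4ccccc4[nH]3)cc2c1` differs from compound 1 in one place: hydrogen in place of benzyl on an aromatic nitrogen. Among the compounds with values here, with no measured pair to compare against, the size of this step can only be judged from the shared core and the value of compound 1, and the expectation is a step from compound 1 to compound 3 of a 1.9-fold higher number from compound 1 to compound 3 (0.27 log units; within the scatter) in this assay, in the direction of weaker inhibition, though a change within the scatter cannot be ruled out. For compound 3 an estimated value of 40000 nM is taken, with a range from 10000 nM to 150000 nM. This expectation rests on compound 1, which already gives 21500 nM, so a weak result for compound 3 would not be surprising.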

Compound 3, half-maximal inhibitory concentration: 6200 nM
The estimate for compound 3 lay 6.5-fold (0.81 log units) above the measured number; the whole stated range lies above it.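

In this assay, going by these compounds alone, hydrogen in place of benzyl on the aromatic nitrogen gives a 3.5-fold lower number from compound 1 to compound 3 (0.54 log units; beyond the scatter), the first measured step. The benzyl is therefore not required for the antiproliferative effect at this position, and the unsubstituted nitrogen of compound 3 gives the stronger inhibition of the pair, although compound 3, at 6200 nM, remains a weak inhibitor on this read-out. Nothing available explains why the number falls on losing the benzyl, so the step stands as an observation only.

As far as these compounds go, with only hydrogen and benzyl compared at this nitrogen, it stays open whether a methyl group, a longer chain such as phenethyl, or a chain ending in a carboxylic acid or an amine would keep the number of compound 3 or return it towards that of compound 1. Steps involving compound 2 cannot be read in this assay, so the effect of its benzoyl group on the shared core also stays open, as does whether the gain from removing the benzyl would carry over to a compound bearing that group.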